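The source may report more compounds than this note shows. Statements on the series, on what has been measured and on what is new or still open speak of the compounds shown alone.

Compounds measured in an assay (Cricetulus griseus) for inhibition of aldehyde dehydrogenase, mitochondrial (Homo sapiens); on this read-out lower numbers stand for stronger inhibition and higher numbers for weaker inhibition:
compound 1 `CCOC(=O)CCCCOc1ccc2c(=O)c(-c3ccc(O)cc3)coc2c1` gives 240 nM;
compound 2 `O=c1c(-c2ccc(O)cc2)coc2cc(OCCCCCCCCCCCCO)ccc12` gives 1700 nM;
compound 3 `C=CCOc1ccc2c(=O)c(-c3ccc(O)cc3)coc2c1` gives 180 nM.

Compound 1 stands second highest of the three numbers, within the scatter of compound 3 and well apart from compound 2. Compound 4 `C=CCCCCOc1ccc2c(=O)c(-c3ccc(O)cc3)coc2c1` has not yet been measured; it differs from compound 1 in one place: vinyl in place of ethoxycarbonyl on a saturated chain carbon, four bonds along the chain from an oxygen on an aromatic ring. Among the measured compounds shown here, two measured steps bear on this. The step of a 1.3-fold lower number from compound 1 to compound 3 (0.12 log units; within the scatter) shows that removing the ester while shortening the ether chain changes little. The step of a 7.1-fold higher number from compound 1 to compound 2 (0.85 log units; beyond the scatter) shows that lengthening the chain with a hydroxyl end weakens inhibition. Compound 4 keeps a chain of similar length to compound 1 but loses the ester, so the expected step is a 1.2-fold lower number from compound 1 to compound 4 (0.08 log units; within the scatter), within the scatter. Compound 4 is estimated at 200 nM, between 80 nM and 500 nM.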

Compound 4, half-maximal inhibitory concentration: 150 nM
Beside the measured number, compound 4's estimate is 1.3-fold (0.12 log units) above it; measured number inside the range.
By their numbers in this assay, from the lowest: compounds 4, 3 and 1 (each within the scatter of the next); then compound 2.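

In this assay, the ester end of the chain proves dispensable at this place, four bonds along the chain from an oxygen on an aromatic ring: vinyl in place of ethoxycarbonyl gives a 1.6-fold lower number from compound 1 to compound 4 (0.20 log units; within the scatter). Chain length also makes no readable difference between the two alkene ethers, with pent-4-en-1-yl in place of vinyl giving a 1.2-fold lower number from compound 3 to compound 4 (0.08 log units; within the scatter). Against the 8-hydroxyoctyl end, vinyl gives an 11-fold lower number from compound 2 to compound 4 (1.05 log units; beyond the scatter), so compound 2 alone stands apart.

Nothing available explains that gap. As far as these compounds go, whether an amine, a carboxylic acid or a longer chain ending in vinyl would keep compound 4's level remains open.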